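Thiophenyl Replaces Chlorophenyl on the Sulfonamide

A few compounds are considered here, and "the series" means these few. Any claim that something is new, unique, unknown or untested is made for them only; others in the source may bear on it.

Compound 2 `O=S(=O)(Nc1ccc(-c2nc3ccccc3o2)cc1)c1cccc(Cl)c1` gives 54000 nM in an assay on cells for inhibition of HSP60/HSP10 (Homo sapiens), with a stated time of 60 min (a higher number here means a weaker inhibitor, a lower number a stronger inhibitor), the highest of the two numbers measured, though only within the scatter of compound 1. Compound 1 `O=S(=O)(Nc1ccc(-c2nc3ccccc3o2)cc1)c1ccc(Cl)s1` gives 31000 nM in this assay, and the step of a 1.7-fold higher number from compound 1 to compound 2 (0.24 log units; within the scatter) exchanges the aryl group on the sulfonyl sulfur. Compound 3 `O=S(=O)(Nc1ccc(-c2nc3ccccc3o2)cc1)c1cccs1` carries the change (thiophen-2-yl in place of 3-chlorophenyl on a sulfonyl sulfur). Within the data shown here, the only step that bears on it is this aryl exchange, which stayed within the scatter, and no measured step removes a chlorine. The expected step of a 1.2-fold higher number from compound 2 to compound 3 (0.08 log units; within the scatter) in this assay is therefore modest, leaning toward a higher number. Compound 3 is estimated at 65000 nM, between 25000 nM and 170000 nM.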

Compound 3, half-maximal inhibitory concentration: 63000 nM
Beside the measured number, compound 3's estimate is 1.0-fold (0.01 log units) above it; the range from low to high includes it.
By their numbers in this assay, from the lowest: compounds 1, 2 and 3 (each within the scatter of the next, the first and the last beyond it).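

Thiophen-2-yl in place of 3-chlorophenyl on a sulfonyl sulfur gives a 1.2-fold higher number from compound 2 to compound 3 (0.07 log units; within the scatter) in this assay and so, like the earlier aryl exchange, stays within the scatter. Hydrogen in place of chloro on an aromatic carbon gives a 2.0-fold higher number from compound 1 to compound 3 (0.31 log units; beyond the scatter) and is the first step here beyond the scatter, though a modest one. Nothing available accounts for this step.

As far as these compounds go, it remains open whether bromo or methyl on that aromatic carbon would match compound 1, and how an amine or a carboxylic acid there would read.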